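A few compounds are considered here, and "the series" means these few. Any claim that something is new, unique, unknown or untested is made for them only; others in the source may bear on it.

Measured compounds and their values in the assay described below:

Compound 1 `CC(C)n1ncc2c(C(=O)NCc3ccccc3)cccc21`: > 40000 nM
Compound 2 `Cc1ccc(-n2cc(CNC(=O)c3cccc4c3cnn4C(C)C)nn2)c(C)c1`: > 40000 nM
Compound 3 `CC(C)n1ncc2c(C(=O)NCc3cn(-c4ccc(I)cc4)nn3)cccc21`: > 40000 nM

In a functional assay on MGC-803 cells (Homo sapiens) for inhibition, read by MTT assay, with a stated time of 72 h (on this read-out lower numbers stand for stronger inhibition and higher numbers for weaker inhibition), compound 1 gives > 40000 nM, which is a limit of the assay and not a number. In this assay compound 2 gives > 40000 nM, likewise a limit. In this assay compound 3 gives > 40000 nM, again a limit. Compound 3 therefore stands nowhere on a scale of numbers: all three values shown sit at the limit of > 40000 nM in this assay, at which 3 of the 3 values shown sit, and none of the three can be ordered against the others.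

Among the compounds with values here, the only measured step with one change, a step that the two limits leave unreadable from compound 2 to compound 3, runs between two limits and yields no readable size. Within the data shown here, it is the sole step bearing on the change from compound 3 to compound 4, which is 3-fluorophenyl in place of 4-iodophenyl on an aromatic nitrogen; compound 4 has the structure `CC(C)n1ncc2c(C(=O)NCc3cn(-c4cccc(F)c4)nn3)cccc21`.

With nothing but limits behind the series, the expected step that the limit leaves unreadable from compound 3 to compound 4 is taken as none beyond the scatter, and compound 4 is most likely to return another limit. The estimate for compound 4 in this assay is 60000 nM, with an expected range from 20000 nM to 200000 nM.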

Compound 4, half-maximal inhibitory concentration: > 40000 nM
Compound 4 gave a limit, no number (the forecaster's own chance of this, stated with the estimate: 85%); the middle value is on the limit's open side.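

In this assay compound 4 gives > 40000 nM, a limit of the assay and not a number. No new step can be read, as compound 2, compound 3 and compound 4 all sit at limits. The compounds shown leave open whether any aryl group on the aromatic nitrogen would give a measurable value in this assay.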